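Adding a Trifluoromethyl Group to the Pyrimidine Ring

The source may report more compounds than this note shows. Statements on the series, on what has been measured and on what is new or still open speak of the compounds shown alone.

For the measured compounds named here, compound 2 `Fc1cc2nc(-c3cncnc3)n(C3CC3)c2cc1F` gives 2270 nM in an ADME assay on cells for inhibition of cytochrome P450 11B1, mitochondrial (Homo sapiens), read by HPLC, with a stated time of 60 min (on this read-out lower numbers stand for stronger inhibition and higher numbers for weaker inhibition), the lowest of the two numbers measured so far; compound 1 `Fc1ccc2nc(-c3cncnc3)n(C3CC3)c2c1` gives 5380 nM, and the step of a 2.4-fold lower number from compound 1 to compound 2 (0.37 log units; beyond the scatter) is the only measured one. Compound 3 `Fc1cc2nc(-c3cncnc3C(F)(F)F)n(C3CC3)c2cc1F` differs from compound 2 by trifluoromethyl in place of hydrogen on an aromatic carbon. That measured step concerns a fluoro group elsewhere and does not bear on this change, so nothing measured guides it. A modest weakening is expected, a 1.8-fold higher number from compound 2 to compound 3 (0.25 log units; within the scatter). Compound 3 is therefore estimated at 4000 nM in this assay, within a range of 1000 nM to 16000 nM.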

Compound 3, half-maximal inhibitory concentration: 4770 nM
Beside the measured number, compound 3's estimate is 1.2-fold (0.08 log units) below it, within the range that was stated.
By their numbers in this assay, from the lowest: compound 2; then compounds 3 and 1 (each within the scatter of the next).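

In this assay, trifluoromethyl in place of hydrogen on an aromatic carbon of the six-membered aromatic ring with 2 nitrogen gives a 2.1-fold higher number from compound 2 to compound 3 (0.32 log units; beyond the scatter). For the compounds shown here, this is the first measured change on that ring, and it shows a modest weakening of inhibition: the position accepts this larger group with only a limited loss. Nothing available explains the weakening. With only trifluoromethyl shown at this carbon, one step cannot establish a trend. On these data alone, how a methyl, an amine or a methoxy group would behave there remains open.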